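This account rests on a few compounds, and the source may have more. Where it says the series, first, only, none or still open, it means among the compounds named here.

Compound 1, `Cc1cc(O)c(C(=O)/C=C/c2ccccc2)c(-c2ccc(Br)cc2)c1C(=O)/C=C/c1ccccc1`, carries a bromo group on one aromatic ring. In a functional assay on MCF7 cells (Homo sapiens) for cytotoxicity, read by MTT assay, with a stated time of 24 h (a lower number here means a stronger inhibitor, a higher number a weaker inhibitor), compound 1 gives 10000 nM. Compound 2, `Cc1cc(O)c(C(=O)/C=C/c2ccc(OCc3ccccc3)cc2)c(-c2ccc(Br)cc2)c1C(=O)/C=C/c1ccc(OCc2ccccc2)cc1`, gives 20000 nM, and compound 3, `Cc1cc(O)c(C(=O)/C=C/c2ccc(OCc3ccccc3)cc2)c(-c2ccc(OCc3ccccc3)cc2)c1C(=O)/C=C/c1ccc(OCc2ccccc2)cc1`, gives 26000 nM. Compound 2 and compound 3 differ in one place: benzyloxy in place of bromo on an aromatic carbon. That change made a 1.3-fold higher number from compound 2 to compound 3 (0.11 log units; within the scatter). The difference between the cores of compound 1 and compound 2 is not broken down here. Compound 4, `Cc1cc(O)c(C(=O)/C=C/c2ccccc2)c(-c2ccc(OCc3ccccc3)cc2)c1C(=O)/C=C/c1ccccc1`, has not yet been measured; it differs from compound 1 by the same change, (benzyloxy in place of bromo on an aromatic carbon). Since the matching step stayed within the scatter, a similar small step is expected here, amounting to a 1.3-fold higher number from compound 1 to compound 4 (0.11 log units; within the scatter). Compound 4 is therefore expected to give about 13000 nM, most likely between 7000 nM and 25000 nM.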

Compound 4, half-maximal inhibitory concentration: "not active" (no number reported)
The entry for compound 4 holds no number, so the estimate cannot be set against anything.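

For the compounds shown here, compound 4 is reported only as "not active", with no number, so no step from compound 1 to compound 4 can be read. Nothing measured here offers an explanation. From the compounds shown here alone, how large the effect of benzyloxy in place of bromo is in this assay on the core of compound 1 stays open.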